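The source may hold more compounds than are shown below. What is called first, only, known or untested is meant among the compounds shown, and "the series" means these compounds.

Measured so far in an ADME assay on isolated protein for inhibition of Amine oxidase [flavin-containing] B (Homo sapiens); a lower number here means a stronger inhibitor, a higher number a weaker inhibitor:
compound 1 `C#CCNC1CCc2c(SCCc3cccc(C)c3)cccc21`: 4960 nM
compound 2 `C#CCNC1CCc2c(OCc3cccc(C(F)(F)F)c3)cccc21`: 5410 nM
compound 3 `C#CCNC1CCc2c(SCc3ccc(C)cc3)cccc21`: 320 nM

Compound 1 stands second highest of the three numbers. Compound 2 lies within the scatter of it, so the two cannot be ordered. Compound 3 gives a markedly lower number, beyond the scatter.

Compound 4 `C#CCNC1CCc2c(SCCc3ccc(C)cc3)cccc21` is not yet measured. It differs from compound 1 in one place: 4-methylphenyl in place of 3-methylphenyl on a saturated chain carbon, two bonds along the chain from a sulfur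

Going by the values given here, no single-change step between measured compounds is available to size this move. Compound 3 also bears 4-methylphenyl and gives 320 nM, though it differs from compound 1 in more than one place. A modest step down is expected, a 2.0-fold lower number from compound 1 to compound 4 (0.30 log units; within the scatter). For compound 4 the estimate is 2500 nM, between 800 nM and 8000 nM.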

Compound 4, half-maximal inhibitory concentration: 4520 nM
Estimate against measurement, compound 4: 1.8-fold (0.26 log units) below; the measured number falls inside the stated range.
By their numbers in this assay, from the lowest: compound 3; then compounds 4, 1 and 2 (each within the scatter of the next).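

In this assay, 4-methylphenyl in place of 3-methylphenyl on a saturated chain carbon, two bonds along the chain from a sulfur, gives a 1.1-fold lower number from compound 1 to compound 4 (0.04 log units; within the scatter), so the two isomers cannot be ordered. At this position, this shift of the methyl therefore leaves no readable difference in the half-maximal inhibitory concentration. No measured property is available that bears on this result.

Open, going by these compounds, is whether a plain phenyl, a 2-methylphenyl or a 4-methoxyphenyl at the same place would give a different number. Also open, on these data alone, is how a longer chain would read with either methylphenyl group.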